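A few compounds are considered here, and "the series" means these few. Any claim that something is new, unique, unknown or untested is made for them only; others in the source may bear on it.

Compound 1 `O=C(CN1CCNCC1)N1CCC(NS(=O)(=O)c2cc(S(=O)(=O)c3ccccc3)ccc2C(F)(F)F)CC1` is the reference point of this small series. In a functional assay on U2OS cells for antagonist activity at proto-oncogene Wnt-3 (Homo sapiens), read by a luciferase reporter, with a stated time of 18 h (a lower number here means that less compound is needed, a higher number that more compound is needed for the effect), compound 1 gives 250 nM, the highest of the three numbers recorded, though compound 3 is its nearest neighbour and compound 2 the furthest, both within the scatter of it. Compound 2 `CC(C)(C)OC(=O)N1CCC[C@@H]1C(=O)N1CCC(NS(=O)(=O)c2cc(S(=O)(=O)c3ccccc3)ccc2C(F)(F)F)CC1` gives 210 nM in this assay, and compound 3 `CN1CCC[C@H]1C(=O)N1CCC(NS(=O)(=O)c2cc(S(=O)(=O)c3ccccc3)ccc2C(F)(F)F)CC1` gives 230 nM. The recorded steps are all small: a 1.2-fold lower number from compound 1 to compound 2 (0.08 log units; within the scatter), a 1.1-fold lower number from compound 1 to compound 3 (0.04 log units; within the scatter) and a 1.1-fold higher number from compound 2 to compound 3 (0.04 log units; within the scatter).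

Compound 4 `O=C([C@@H]1CCCN1Cc1ccccc1)N1CCC(NS(=O)(=O)c2cc(S(=O)(=O)c3ccccc3)ccc2C(F)(F)F)CC1` is not yet measured. Relative to compound 1 the change is 1-benzylpyrrolidin-2-yl in place of (piperazin-1-yl)methyl on a carbonyl carbon. The steps from compound 1 to compound 2 and from compound 1 to compound 3 bear directly on it, since both also exchange the (piperazin-1-yl)methyl for a substituted pyrrolidin-2-yl, and neither moved the number beyond the scatter. The expectation for compound 4 is therefore no step beyond the scatter, a 1.1-fold lower number from compound 1 to compound 4 (0.04 log units; within the scatter). Compound 4 is estimated at 230 nM, with a range from 110 nM to 480 nM.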

Compound 4, half-maximal effective concentration: 720 nM
Compound 4: the middle estimate sits 3.1-fold (0.50 log units) below what was measured, and the stated range ends below it.
By their numbers in this assay, from the lowest: compounds 2, 3 and 1 (each within the scatter of the next); then compound 4.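

In this assay, going by these compounds alone, this position on the carbonyl carbon proves less permissive than the earlier steps suggested: 1-benzylpyrrolidin-2-yl in place of (piperazin-1-yl)methyl gives a 2.9-fold higher number from compound 1 to compound 4 (0.46 log units; beyond the scatter), whereas the earlier exchanges stayed within the scatter. The pyrrolidin-2-yl ring is shared by compound 2, compound 3 and compound 4, yet phenyl in place of hydrogen on the methyl group of the 1-methylpyrrolidin-2-yl gives a 3.1-fold higher number from compound 3 to compound 4 (0.50 log units; beyond the scatter), and 1-benzylpyrrolidin-2-yl in place of 1-(tert-butoxycarbonyl)pyrrolidin-2-yl gives a 3.4-fold higher number from compound 2 to compound 4 (0.54 log units; beyond the scatter), so the higher number goes with the benzyl group in this set. Nothing available explains this step.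

The compounds shown leave open whether a cyclohexylmethyl or 2-phenylethyl group in place of the benzyl would track compound 4 or compound 3. They also leave open how the opposite configuration at the stereocentre of compound 4 would read.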